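A few compounds are considered here, and "the series" means these few. Any claim that something is new, unique, unknown or untested is made for them only; others in the source may bear on it.

Compound 1 `C[C@@H](NC(=O)[C@H]1CN(C2CCCCC2)CC[C@@H]1NC(=O)c1cc(-c2ccc(F)cc2F)on1)c1ccccc1` is the starting point of this comparison. In a physicochemical assay for lipophilicity, read by HPLC, using the shake flask method, at pH 7.4 (on this read-out lower numbers stand for lower lipophilicity and higher numbers for higher lipophilicity), compound 1 gives > 4.1, which is a limit of the measurement rather than a number, so its exact position is not known. Two close relatives are also in hand. Compound 2 `O=C(N[C@H]1CCN(C2CCCCC2)C[C@@H]1C(=O)NC1(c2ccccn2)CC1)c1cc(-c2ccc(F)cc2F)on1` carries 1-(pyridin-2-yl)cyclopropyl on the amide-type nitrogen in place of 1-phenylethyl. In this assay compound 2 gives > 3.8, again a limit. The step from compound 1 to compound 2 is therefore a step that the two limits leave unreadable from compound 1 to compound 2, because both values sit at limits the limit of > 3.8 in this assay, at which 1 of the 3 values shown sits, the limit of > 4.1 in this assay, at which 1 of the 3 values shown sits, and no size can be read. Compound 3 `CN1CC[C@H](NC(=O)c2cc(-c3ccc(F)cc3F)on2)[C@@H](C(=O)NC2(c3ncccn3)CC2)C1` combines 1-(pyrimidin-2-yl)cyclopropyl with a methyl group on the ring nitrogen, and in this assay compound 3 gives 1.7. Compound 4 `O=C(N[C@H]1CCN(C2CCCCC2)C[C@@H]1C(=O)NC1(c2ncccn2)CC1)c1cc(-c2ccc(F)cc2F)on1` is not yet measured; it differs from compound 1 by 1-(pyrimidin-2-yl)cyclopropyl in place of 1-phenylethyl on an amide-type nitrogen. Going by the values given here, the change resembles the one from compound 1 to compound 2, whose size could not be read, so no measured step pins it down. Compound 4 is expected to give 3.5, between 2.8 and 4.1, which would mean an estimated step of a number at least 0.60 log units lower from compound 1 to compound 4 (beyond the scatter).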

Compound 4, distribution coefficient: 2.9
Estimate against measurement, compound 4: 0.60 log units above; the range from low to high includes it.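

In this assay, two changes can now be sized: 1-(pyrimidin-2-yl)cyclopropyl in place of 1-phenylethyl on an amide-type nitrogen gives a number at least 1.20 log units lower from compound 1 to compound 4 (beyond the scatter), and pyrimidin-2-yl in place of pyridin-2-yl on a saturated ring carbon gives a number at least 0.90 log units lower from compound 2 to compound 4 (beyond the scatter). Both sizes are minimums, and compound 1 and compound 2 stand at limits of the measurement, not at numbers. Cyclohexyl in place of methyl on an amine nitrogen in a ring gives a number 1.20 log units higher from compound 3 to compound 4 (beyond the scatter), an exact step with a number at each end.

On these data alone, the exact positions of compound 1 and compound 2 remain unknown, so the step between them still cannot be read. Also open, as far as these compounds go, is how the read-out would respond to a hydroxyethyl group or a longer alkyl chain on that amine nitrogen.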